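This account rests on a few compounds, and the source may have more. Where it says the series, first, only, none or still open, it means among the compounds named here.

Three compounds share one core. Compound 1 `c1ccc(-c2cccc3c2CCC3c2ncc[nH]2)nc1` carries pyridin-2-yl on an aromatic carbon and gives 53% in a functional assay on CHO cells for agonist activity at Alpha-1A adrenergic receptor (Homo sapiens), read by FLIPR and calcium flux; a lower number here means a smaller maximal response, a higher number a larger maximal response. Compound 2 `Cn1ccc(-c2cccc3c2CCC3c2ncc[nH]2)n1` carries 1-methyl-1H-pyrazol-3-yl in the same place; in this assay compound 2 gives 19%. Compound 3 `CNC(=O)c1cccc2c1CCC2c1ncc[nH]1` carries methylcarbamoyl there, and in this assay compound 3 gives 59%, the highest of the three numbers, although its separation from compound 1 is within the scatter. Of the steps, a number 34 percentage points lower from compound 1 to compound 2 (beyond the scatter) and a number 40 percentage points higher from compound 2 to compound 3 (beyond the scatter) are large, whereas a number 6 percentage points higher from compound 1 to compound 3 (within the scatter) is within the scatter.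

Compound 4 `c1cc(-c2ncco2)c2c(c1)C(c1ncc[nH]1)CC2` has not yet been measured in this assay. It differs from compound 3 in one place: 1,3-oxazol-2-yl in place of methylcarbamoyl on an aromatic carbon. Going by the values given here, two measured steps bear on this change. Exchanging the six-membered aromatic pyridin-2-yl for methylcarbamoyl changed little, a number 6 percentage points higher from compound 1 to compound 3 (within the scatter), while exchanging the five-membered aromatic 1-methyl-1H-pyrazol-3-yl for methylcarbamoyl gave a number 40 percentage points higher from compound 2 to compound 3 (beyond the scatter). The entering 1,3-oxazol-2-yl is, like the group of compound 2, a five-membered aromatic ring with 2 hetero atoms, yet it lacks the methyl and has 2 hydrogen-bond acceptors. Compound 4 is therefore expected to land between those two precedents, with an estimated step of a number 19 percentage points lower from compound 3 to compound 4 (beyond the scatter). The expected value for compound 4 is 40%, with a range from 15% to 65%.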

Compound 4, largest response reached (Emax), in percent of the reference or control that the assay uses: 63%
Compound 4: middle estimate off by 23 percentage points, on the low side; measured number inside the range.
By their numbers in this assay, from the lowest: compound 2; then compounds 1, 3 and 4 (each within the scatter of the next).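

In this assay, exchanging 1-methyl-1H-pyrazol-3-yl for 1,3-oxazol-2-yl gives a number 44 percentage points higher from compound 2 to compound 4 (beyond the scatter), so a five-membered aromatic ring with 2 hetero atoms on this aromatic carbon does not by itself bring a low maximal response. The other two steps, a number 4 percentage points higher from compound 3 to compound 4 (within the scatter) and a number 10 percentage points higher from compound 1 to compound 4 (within the scatter), show that 1,3-oxazol-2-yl cannot be told apart from methylcarbamoyl or pyridin-2-yl at this position, even though the exchange for methylcarbamoyl removes its hydrogen-bond donor, and among the four groups only the 1-methyl-1H-pyrazol-3-yl of compound 2 stands apart. Nothing measured here accounts for the separate place of compound 2.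

The compounds shown leave open whether the methyl or the pyrazole ring itself sets compound 2 apart, a question that an unsubstituted 1H-pyrazol-3-yl on this aromatic carbon would address. Going by these compounds, it also remains open how an amine or a carboxylic acid at this position would behave in this assay, and whether any group there can lift the response clearly beyond that of compounds 1, 3 and 4.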